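Hydrazone aryl swap: dimethoxyphenyl for trifluoromethylphenyl

The source may report more compounds than this note shows. Statements on the series, on what has been measured and on what is new or still open speak of the compounds shown alone.

Compound 2 `Cn1c(=O)c(=O)n(C2CCCC2)c2nc(N/N=C/c3ccc(C(F)(F)F)cc3)ncc21` gives 23600 nM in a functional assay on PC-3 cells (Homo sapiens) for antiproliferative activity, read by MTT assay (on this read-out lower numbers stand for stronger inhibition and higher numbers for weaker inhibition), the highest of the three numbers recorded. Compound 3 `Cn1c(=O)c(=O)n(C2CCCC2)c2nc(N/N=C/c3cc(C(F)(F)F)c(O)c(C(F)(F)F)c3)ncc21` gives 17700 nM in this assay, within the scatter of compound 2. Compound 1 `Cn1c(=O)c(=O)n(C2CCCC2)c2nc(N/N=C/c3ccc(Cl)cc3)ncc21` gives 8420 nM, and the step of a 2.8-fold higher number from compound 1 to compound 2 (0.45 log units; beyond the scatter) lies beyond the scatter. Compound 4 `COc1ccc(/C=N/Nc2ncc3c(n2)n(C2CCCC2)c(=O)c(=O)n3C)c(OC)c1` differs from compound 2 by 2,4-dimethoxyphenyl in place of 4-(trifluoromethyl)phenyl on a carbon with a double bond to nitrogen. Among the measured compounds shown here, only the step from compound 1 to compound 2 bears on an aryl swap at this position, and no measured step covers methoxy groups. Compound 4 is therefore expected to land near the measured range, with the estimated step of a 2.1-fold lower number from compound 2 to compound 4 (0.33 log units; beyond the scatter) taken as a modest move toward a lower number, close to the scatter. Compound 4 is estimated at 11000 nM, range 3500 nM to 35000 nM.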

Compound 4, half-maximal inhibitory concentration: > 100000 nM
Compound 4 was reported as a limit; the forecaster's own chance of this, stated with the estimate: 10%; middle value at least 9.0-fold (0.95 log units) from the limit.
By their numbers in this assay, from the lowest: compound 1; then compounds 3 and 2 (each within the scatter of the next). At a limit, above all of these: compound 4.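

In this assay compound 4 is reported only as a limit: the limit of > 100000 nM in this assay, at which 1 of the 4 values shown sits. Bringing in 2,4-dimethoxyphenyl gives an at least 4.2-fold higher number from compound 2 to compound 4 (0.62 log units; beyond the scatter) and an at least 11-fold higher number from compound 1 to compound 4 (1.07 log units; beyond the scatter), so the aryl group at this position can cost more activity than the swap of chloro for trifluoromethyl had shown. From the compounds shown here alone, both steps are open-ended, and their true size remains unknown.

Going by these compounds, whether the loss needs both methoxy groups or follows from one alone stays open. Also open, on these data alone, is how an amine or a carboxylic acid on this aryl ring would read.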